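The compounds below may be only part of what the source reports. "The series", "measured", "known", "first", "only" and "open" are said of these compounds alone.

Series notes. Compound 1 `COc1ccccc1Nc1nc(SCc2cn(Cc3ccccc3Cl)nn2)nc(-c2ccccc2)c1C#N` and compound 2 `Cc1ccccc1Nc1nc(SCc2cn(Cc3ccccc3Cl)nn2)nc(-c2ccccc2)c1C#N` share a core and differ only in the group on the aniline ring. In a functional assay on MCF7 cells (Homo sapiens) for inhibition, read by MTT assay, with a stated time of 72 h (on this read-out higher numbers stand for weaker inhibition and lower numbers for stronger inhibition), compound 1 gives 6170 nM. In this assay compound 2 gives 7950 nM; the step of a 1.3-fold higher number from compound 1 to compound 2 (0.11 log units; within the scatter) is one of methyl in place of methoxy on an aromatic carbon. Compound 3 `Cc1ccc(Cn2cc(CSc3nc(Nc4ccccc4C)c(C#N)c(-c4ccccc4)n3)nn2)cc1` carries a 4-methylphenyl in place of the 2-chlorophenyl of compound 2 on the chain carbon bound to the triazole nitrogen. In this assay, among the measured compounds shown here, compound 3 gives only a limit, > 64000 nM, so its position is known only as being at that limit (the limit of > 64000 nM in this assay, at which 1 of the 3 values shown sits); the step of an at least 8.0-fold higher number from compound 2 to compound 3 (0.90 log units; beyond the scatter) is the one clearly resolved change in this set.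

Compound 4 `Cc1ccc(Cn2cc(CSc3nc(Nc4ccc(C)cc4)c(C#N)c(-c4ccccc4)n3)nn2)cc1` differs from compound 3 by 4-methylphenyl in place of 2-methylphenyl on a nitrogen on an aromatic ring. For the measured compounds named here, no measured step moves the methyl around the aniline ring; the one change on that ring, from compound 1 to compound 2, stayed within the scatter, and the one change that moved the number, from compound 2 to compound 3, lies on a different part of the molecule. Compound 3 already sits at the limit, so compound 4 is expected to remain there or near it, giving an expected step that the limit leaves unreadable from compound 3 to compound 4. The estimate for compound 4 in this assay is 70000 nM, with a range from 20000 nM to 250000 nM.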

Compound 4, half-maximal inhibitory concentration: > 64000 nM
Compound 4: only a limit was reported (the forecaster's own chance of this, stated with the estimate: 65%); the middle value lies beyond the limit too.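

In this assay compound 4 gives > 64000 nM as a limit of the assay, not as a number. Among the compounds shown here, no step between compound 3 and compound 4 can be read, because both compounds stand at a limit: the limit of > 64000 nM in this assay, at which 2 of the 4 values shown sit. The compounds shown leave open whether 4-methylphenyl in place of 2-methylphenyl on that nitrogen changes the read-out at all.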